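The compounds below may be only part of what the source reports. "The series", "measured", "known", "first", "only" and "open" are said of these compounds alone.

Compound 1, `Cc1oc(-c2c(Cl)cccc2Cl)nc1CN1CCC(C(=O)NCCCN2C[C@H](C)C[C@H](C)C2)CC1`, sits at 13200 nM in an ADME assay on Huh7.5.1 cells (Homo sapiens) for cytotoxicity, read by ATP content, with a stated time of 48 h; on this read-out higher numbers stand for lower toxicity in this test and lower numbers for higher toxicity in this test; it holds the second highest of the three numbers shown, with compound 3, `CCCN(CCC)CCNC(=O)C1CCN(Cc2nc(-c3ccccc3C)oc2C)CC1`, at 30500 nM above it and compound 2, `Cc1ccccc1-c1nc(CN2CCC(C(=O)NCCCN3CCCC(CC(C)C)C3)CC2)c(C)o1`, at 4640 nM below it. Within the data shown here, the only single-place step measured here runs a 6.6-fold higher number from compound 2 to compound 3 (0.82 log units; beyond the scatter), and it concerns the amine-bearing chain, not the aryl group. Compound 4, `Cc1ccc(-c2nc(CN3CCC(C(=O)NCCCN4C[C@H](C)C[C@H](C)C4)CC3)c(C)o2)cc1C`, differs from compound 1 by 3,4-dimethylphenyl in place of 2,6-dichlorophenyl on an aromatic carbon. Among the measured compounds shown here, no measured pair isolates this aryl change: compound 2 carries a different aryl group but also a different amine, so its value and that of compound 1 can only be set side by side, not read as a step. The chain is unchanged between compound 1 and compound 4, so the expected movement in this assay is small, a 1.1-fold lower number from compound 1 to compound 4 (0.04 log units; within the scatter), with no direction favoured beyond the scatter. Compound 4 is therefore estimated at 12000 nM, within 4500 nM to 32000 nM.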

Compound 4, half-maximal cytotoxic concentration: 6910 nM
Compound 4: the middle estimate sits 1.7-fold (0.24 log units) above what was measured; measured number inside the range.
By their numbers in this assay, from the lowest: compounds 2, 4 and 1 (each within the scatter of the next, the first and the last beyond it); then compound 3.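

The aryl position on the shared core now has a step of its own: 3,4-dimethylphenyl in place of 2,6-dichlorophenyl gives a 1.9-fold lower number from compound 1 to compound 4 (0.28 log units; within the scatter) in this assay. Among these compounds, this exchange of two chlorine atoms for two methyl groups, with the position of the substituents also altered, therefore leaves the two compounds indistinguishable in this test, whereas the only earlier step, on the amine-bearing chain, a 6.6-fold higher number from compound 2 to compound 3 (0.82 log units; beyond the scatter), lay beyond the scatter. Nothing shown offers an explanation for this result.

As far as these compounds go, it remains open whether an unsubstituted phenyl, a pyridine ring or a methoxy-bearing phenyl at this place would also stay within the scatter of compound 1 . From the compounds shown here alone, it is equally open whether the same aryl exchange would read alike with the amine-bearing chain of compound 3 .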